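Swapping the acid-bearing aryl of compound 3 for a methoxyphenyl

The source may report more compounds than this note shows. Statements on the series, on what has been measured and on what is new or still open speak of the compounds shown alone.

Measured so far:
- compound 1, `Cc1ncc(OCCCCOc2ccc(C(=O)CC(C)(C)C)c(O)c2C)cc1C(=O)O`: 28 nM
- compound 2, `Cc1c(OCCCCOc2ccc(C(=O)O)c(F)c2)ccc(C(=O)CC(C)(C)C)c1O`: 80 nM
- compound 3, `Cc1c(OC[C@@H](C)COc2ccc(Cl)c(C(=O)O)c2)ccc(C(=O)CC(C)(C)C)c1O`: 377 nM

In an assay for positive allosteric modulation of metabotropic glutamate receptor 2 (Rattus norvegicus) (a higher number here means that more compound is needed for the effect, a lower number that less compound is needed), compound 3 has the highest number of the three, so it needs the most compound for its effect. Both neighbours sit well apart from it, with compound 2 nearer and compound 1 furthest away.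

Compound 4, `COc1ccccc1OC[C@H](C)COc1ccc(C(=O)CC(C)(C)C)c(O)c1C`, has not yet been measured. It differs from compound 3 in one place: 2-methoxyphenyl in place of 3-carboxy-4-chlorophenyl on an oxygen on a saturated carbon. Going by the values given here, the only measured single step, a 2.9-fold higher number from compound 1 to compound 2 (0.46 log units; beyond the scatter), exchanged one carboxy-bearing aryl for another and moved the number only modestly. Among the compounds with values here, no measured step removes the carboxylic acid altogether or introduces a methoxy group, so that part of the change is untested here. Given the modest size of the one known aryl swap, but with the acid absent and compound 3 already starting from 377 nM, a further rise is expected in this assay, on the order of a 4.0-fold higher number from compound 3 to compound 4 (0.60 log units; beyond the scatter). For compound 4 the estimate is therefore 1500 nM, with a range from 300 nM to 8000 nM.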

Compound 4, half-maximal effective concentration: "not active" (no number reported)
No number was reported for compound 4; no gap can be computed for the estimate.
By their numbers in this assay, from the lowest: compound 1; then compound 2; then compound 3.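

Going by these compounds alone, compound 4 was reported as "not active" in this assay, without a number, so no step from compound 3 to compound 4 can be read. Nothing shown accounts for this result. The compounds shown leave open how much of the outcome belongs to losing the carboxylic acid, and how much to the rest of the swap to 2-methoxyphenyl.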